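The compounds below may be only part of what the source reports. "The series", "measured", "known", "first", "only" and "open" are said of these compounds alone.

Compound 1 `N#Cc1c(F)c(Cl)c(C(C(=O)c2ccccc2)=C2NCCN2)c(C#N)c1F` and compound 2 `N#Cc1c(F)c(F)c(C(C(=O)c2ccccc2)=C2NCCN2)c(C#N)c1F` share one core and differ only in a single substituent on the aromatic ring that carries the two nitrile groups. In a functional assay on HL-60 cells (Homo sapiens) for antiproliferative activity, read by MTT assay (on this read-out higher numbers stand for weaker inhibition and lower numbers for stronger inhibition), compound 1 gives 4.7 ug/mL, while compound 2 gives 0.2 ug/mL. The change between them, (fluoro in place of chloro on an aromatic carbon), produced a 24-fold lower number from compound 1 to compound 2 (1.37 log units; beyond the scatter).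

Compound 3 `N#Cc1c(F)c(Cl)c(C(C(=O)c2ccc(F)cc2)=C2NCCCCN2)c(C#N)c1F` is built on a different core; how that core differs from the core of compound 1 is not broken down here. In this assay compound 3 gives 0.1 ug/mL.

Compound 4 `N#Cc1c(F)c(F)c(C(C(=O)c2ccc(F)cc2)=C2NCCCCN2)c(C#N)c1F` has not yet been tested. Going by the values given here, it differs from compound 3 by fluoro in place of chloro on an aromatic carbon, which is the same change as the one that separates compound 1 from compound 2, made at a place described in identical terms. Because compound 1 to compound 2 gave a 24-fold lower number from compound 1 to compound 2 (1.37 log units; beyond the scatter), the expected step in this assay from compound 3 to compound 4 is a 3.3-fold lower number from compound 3 to compound 4 (0.52 log units; beyond the scatter), though with caution, since compound 3 already gives 0.1 ug/mL and the second core may not respond in the same way. For compound 4 the estimate in this assay is therefore 0.03 ug/mL, with a likely range from 0.005 ug/mL to 0.15 ug/mL.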

Compound 4, half-maximal inhibitory concentration: 0.1 ug/mL
Compound 4: middle estimate off by 3.3-fold (0.52 log units), on the low side, and the stated range covers the measured number.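

In this assay, fluoro in place of chloro on an aromatic carbon gives no change at the digits printed from compound 3 to compound 4 (within the scatter). The same swap therefore does not have one fixed effect that can simply be carried from the core of compound 1 to the core of compound 3: the same change on two cores in this assay, a 24-fold lower number (1.37 log units; beyond the scatter) from compound 1 to compound 2 and no change at the digits printed (within the scatter) from compound 3 to compound 4, 24-fold (1.37 log units) apart, beyond the scatter of two such steps. This does not show which structural difference between the two pairs goes with that gap, since they differ in more than one place, and two pairs are too few to set a rule for the series.

The compounds shown leave open how bromo, a methoxy group or an amine on that same aromatic carbon would compare with chloro and fluoro. Going by these compounds alone, they also leave open whether a large step or no visible step would be the more common result of this swap on further cores.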